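Sulfonyl piperidine series: carbonyl replacement at the aryl position

This account rests on a few compounds, and the source may have more. Where it says the series, first, only, none or still open, it means among the compounds named here.

Measured compounds:
- compound 1, `CCOC(=O)[C@@H]1CCCN(S(=N)(=O)c2ccc(S(=O)(=O)N(CC)CC)cc2)C1`: 12100 nM
- compound 2, `CCOC(=O)[C@@H]1CCCN(S(=O)(=O)c2ccc(S(=O)(=O)N(CC)CC)cn2)C1`: 1300 nM
- compound 3, `CCC(CC)S(=O)(=O)c1ccc(S(=O)(=O)N2CCC[C@@H](C(=O)N3CCN(c4nc(C(C)C)no4)CC3)C2)cc1`: 50 nM

All three have been run in a functional assay on MIA PaCa-2 cells (Homo sapiens) for inhibition, read by MTT assay, with a stated time of 7 days; on this read-out higher numbers stand for weaker inhibition and lower numbers for stronger inhibition. Compound 1 gives 12100 nM and compound 2 gives 1300 nM. Compound 3 gives 50 nM, the lowest number of the three; its gap to compound 2 and its larger gap to compound 1 both lie beyond the scatter, so compound 3 is the most potent member measured so far. No pair among these three differs in a single place, so no clean single-change step is available within the measured set.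

The next compound, compound 4, `CCN(CC)C(=O)c1ccc(S(=O)(=O)N2CCC[C@@H](C(=O)N3CCN(c4nc(C(C)C)no4)CC3)C2)cc1`, is obtained from compound 3 by one change: diethylcarbamoyl in place of (pentan-3-yl)sulfonyl on an aromatic carbon. Nothing in the measured set tests this particular exchange, since compounds 1 and 2 differ from compound 3 in several places at once. The expectation therefore rests on compound 3 alone, because its value of 50 nM is the only anchor. A modest weakening is expected, a 2.4-fold higher number from compound 3 to compound 4 (0.38 log units; beyond the scatter), with a wide range that reaches the scatter on the lower side. Compound 4 is estimated at 120 nM in this assay, expected between 30 nM and 500 nM.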

Compound 4, half-maximal inhibitory concentration: 100 nM
For compound 4 the middle estimate is 1.2-fold (0.08 log units) above the measured one, within the range that was stated.
By their numbers in this assay, from the lowest: compounds 3 and 4 (each within the scatter of the next); then compound 2; then compound 1.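

In this assay, going by these compounds alone, diethylcarbamoyl in place of (pentan-3-yl)sulfonyl on an aromatic carbon, para to a large group, gives a 2.0-fold higher number from compound 3 to compound 4 (0.30 log units; within the scatter) and is the first single-place comparison in this set, since compounds 1 and 2 each differ from compound 3 in several places. At this position, then, a sulfonyl group and a carbamoyl group of similar size read alike in this cell assay, and the low value of compound 3 does not depend on keeping the sulfonyl group there: the carbamoyl analogue stays within the scatter of it. Nothing available bears on why the two groups read alike.

This single pair leaves open how far the position accepts other groups, such as a primary amine, a carboxylic acid, a nitrile, or a dimethylcarbamoyl or longer dialkylcarbamoyl group. It also leaves open whether the same exchange reads alike on the core of compound 2, or with a piperidine substituent such as the ethyl ester in place of the amide side of compound 3.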